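A few compounds are considered here, and "the series" means these few. Any claim that something is new, unique, unknown or untested is made for them only; others in the source may bear on it.

Three compounds on a shared core were taken into a functional assay on MCF7 cells (Homo sapiens) for cytotoxicity, read by MTT assay, with a stated time of 72 h (a lower number here means a stronger inhibitor, a higher number a weaker inhibitor), and only one of them gave a number. Compound 2 (`CN(C)CCCNc1c(C(=O)NCc2ccc(F)cc2)nc(Br)c2cccnc12`) gave 7000 nM. Compound 1 (`O=C(NCc1ccc(F)cc1)c1nc(Br)c2cccnc2c1NCc1ccc(F)cc1`) has the entry "not determined" (no result reported), and compound 3 (`O=C(NCc1ccc(F)cc1)c1nc(Br)c2cccnc2c1NCCO`) has the entry "not determined" (no result reported). Among the compounds with values here, compound 3 therefore has no place on the potency scale, and compound 1 is the one other compound left without a number.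

The next compound to be tested is compound 4 (`O=C(NCCCNc1c(C(=O)NCc2ccc(F)cc2)nc(Br)c2cccnc12)c1ccccc1`). The change leading to it is benzamidomethyl in place of hydroxy on a saturated chain carbon, two bonds along the chain from a nitrogen on an aromatic ring, which places benzamidomethyl in place of hydroxy on a saturated chain carbon, two bonds along the chain from a nitrogen on an aromatic ring.

With no number for compound 3, the size of this step cannot be measured from its starting point. Within the data shown here, the only anchor is compound 2 at 7000 nM, and compound 4 is expected to differ from it by no more than the scatter in this assay. For compound 4 the estimated value is 9000 nM, with an expected range from 2500 nM to 30000 nM.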

Compound 4, half-maximal inhibitory concentration: 2000 nM
Estimate against measurement, compound 4: 4.5-fold (0.65 log units) above; the whole stated range lies above it.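

In this assay the reading shows a 3.5-fold lower number from compound 2 to compound 4 (0.54 log units; beyond the scatter) when benzamido stands in place of dimethylamino on a saturated chain carbon, three bonds along the chain from a nitrogen on an aromatic ring. Within the data shown here, until now this position had a single number, so this is the first sign that the group carried on this chain changes the result, and that the dimethylamino group is not needed to keep a measurable value. Nothing measured here accounts for the step.

The step from compound 3 to compound 4 cannot be read, so the result says nothing about how the hydroxy group compares with benzamidomethyl. Whether the gain follows the benzene ring or the amide is open, and an acetamido group or a primary amine at the same place would separate the two.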